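Chain extension on the sulfanyl group of compound 2

A few compounds are considered here, and "the series" means these few. Any claim that something is new, unique, unknown or untested is made for them only; others in the source may bear on it.

Measured compounds:
compound 1 `Cc1nc(N)c2nc(O)n(Cc3ccccc3)c2n1` — 1 uM
compound 2 `CCSc1nc(N)c2nc(O)n(Cc3ccccc3)c2n1` — 0.1 uM

Going by the values given here, in a functional assay (spleen, spleen) for activation, with Mus musculus as the target (on this read-out higher numbers stand for an effect only at larger amounts of compound and lower numbers for an effect already at smaller amounts), compound 2 gives 0.1 uM, the lowest of the two numbers so far; the nearest is compound 1, which in this assay gives 1 uM. Compound 3 `CCCSc1nc(N)c2nc(O)n(Cc3ccccc3)c2n1` has not yet been measured. Its difference from compound 2: methyl in place of hydrogen on a saturated chain carbon, two bonds along the chain from a sulfur.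

Among the compounds with values here, only one measured step exists, a 10-fold lower number from compound 1 to compound 2 (1.00 log units; beyond the scatter). That step exchanged methyl for ethylsulfanyl, so it brought in the sulfur and the chain at the same time and does not separate the contribution of a single further chain carbon from the rest. Within the data shown here, no measured pair adds methyl to a chain that already carries sulfur, so the present change has no direct precedent here.

The expectation for compound 3 is therefore a step near the scatter, if anything toward a lower number, a 1.3-fold lower number from compound 2 to compound 3 (0.10 log units; within the scatter). The estimate for compound 3 in this assay is 0.08 uM, expected to fall between 0.02 uM and 0.3 uM.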

Compound 3, minimum effective concentration: 0.01 uM
Estimate against measurement, compound 3: 8.0-fold (0.90 log units) above; the measured number lies below the stated range.
By their numbers in this assay, from the lowest: compound 3; then compound 2; then compound 1.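

In this assay the added methyl, on a saturated chain carbon two bonds along the chain from a sulfur, gives a 10-fold lower number from compound 2 to compound 3 (1.00 log units; beyond the scatter) and so makes this chain position a sensitive one. The earlier step, a 10-fold lower number from compound 1 to compound 2 (1.00 log units; beyond the scatter), changed the sulfur and the chain together, whereas ethylsulfanyl to propylsulfanyl changes the chain alone and still moves the number beyond the scatter, with the full exchange of methyl for propylsulfanyl on the aromatic carbon amounting to a 100-fold lower number from compound 1 to compound 3 (2.00 log units; beyond the scatter). No measurement at hand bears on the reason for this step.

On these data alone, a single chain extension defines no trend, so it remains open whether a longer chain such as butylsulfanyl or pentylsulfanyl would lower the number further or reverse the change, and whether a branched isopropylsulfanyl would behave like propylsulfanyl. As far as these compounds go, the part played by the sulfur also remains open, as a plain butyl chain or a propoxy group on the same aromatic carbon would be needed to separate it from the chain.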